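The source may report more compounds than this note shows. Statements on the series, on what has been measured and on what is new or still open speak of the compounds shown alone.

Compound 1, `N=S1(=O)CC(Nc2nonc2/C(=N/O)Nc2ccc(F)c(Br)c2)C1`: in an assay on isolated protein for inhibition of Indoleamine 2,3-dioxygenase 1 (Homo sapiens), read by fluorescence, with a stated time of 60 min (on this read-out higher numbers stand for weaker inhibition and lower numbers for stronger inhibition), compound 1 gives 208 nM
Compound 2, `NS(=O)(=O)CCNc1nonc1/C(=N/O)Nc1ccc(F)c(Br)c1`: in this assay compound 2 gives 71 nM
Compound 3, `CCNS(=O)(=O)CCNc1nonc1/C(=N/O)Nc1ccc(F)c(Br)c1`: in this assay compound 3 gives 95 nM

Compound 3 holds the second highest of the three numbers in this assay. Its nearest neighbour is compound 2, and that gap is within the scatter: a 1.3-fold higher number from compound 2 to compound 3 (0.13 log units; within the scatter). Compound 1 lies further away, a 2.2-fold lower number from compound 1 to compound 3 (0.34 log units; beyond the scatter), and the step of a 2.9-fold lower number from compound 1 to compound 2 (0.47 log units; beyond the scatter) points the same way, so both open-chain sulfonamides sit below the four-membered ring of compound 1.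

Compound 4, `O=S(=O)(CCNc1nonc1/C(=N/O)Nc1ccc(F)c(Br)c1)NO`, is reached from compound 3 by one change: hydroxy in place of ethyl on a sulfonamide nitrogen. Within the data shown here, the only measured step that touches the same place is the one from compound 2 to compound 3, where ethyl replaced hydrogen on that sulfonamide nitrogen and the number moved a 1.3-fold higher number from compound 2 to compound 3 (0.13 log units; within the scatter), within the scatter. Among the measured compounds shown here, no measured pair shows a hydroxy on that nitrogen. On that basis the exchange of ethyl for hydroxy is expected to move the number in this assay by little, if at all, in either direction.

The estimate for compound 4 in this assay is therefore 85 nM, with a range from 40 nM to 200 nM; the expected step is a 1.1-fold lower number from compound 3 to compound 4 (0.05 log units; within the scatter).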

Compound 4, half-maximal inhibitory concentration: 126 nM
The estimate for compound 4 lay 1.5-fold (0.17 log units) below the measured number; low and high end bracket the measured number.
By their numbers in this assay, from the lowest: compounds 2, 3, 4 and 1 (each within the scatter of the next, the first and the last beyond it).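

Among these compounds, with hydroxy, the sulfonamide nitrogen now carries a third kind of group, and in this assay neither a 1.3-fold higher number from compound 3 to compound 4 (0.12 log units; within the scatter) nor a 1.8-fold higher number from compound 2 to compound 4 (0.25 log units; within the scatter) leaves the scatter, so no step at this nitrogen has yet gone beyond it, whether the entering group has one hydrogen-bond donor and one acceptor, as hydroxy does, or neither, as ethyl does. Compound 4 also differs from the other two open-chain sulfonamides in one respect: both of those lie beyond the scatter from the four-membered ring of compound 1, whereas here the step is a 1.7-fold lower number from compound 1 to compound 4 (0.22 log units; within the scatter), so the earlier separation of open chain from ring does not hold for all three open-chain compounds. Nothing measured here accounts for these numbers.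

As far as these compounds go, whether a methoxy or a phenyl on the sulfonamide nitrogen would also stay within the scatter of compounds 2, 3 and 4 remains open. Also open, from the compounds shown here alone, is what a carboxylic acid in place of the whole sulfonamide, or a longer chain carrying the sulfonamide, would do to the number.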